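The source may hold more compounds than are shown below. What is called first, only, known or untested is meant among the compounds shown, and "the series" means these compounds.

In a functional assay on U-251 cells (Homo sapiens) for antiproliferative activity, read by MTT assay, with a stated time of 24 h (on this read-out lower numbers stand for stronger inhibition and higher numbers for weaker inhibition), three compounds sharing one core have been measured. Compound 1 (`COc1cc(OC)c(-c2coc3cc(OCc4ccccc4C)ccc3c2=O)cc1OC`) gives 2000 nM, compound 2 (`COc1cc(OC)c(-c2coc3cc(OCc4ccc(C#N)cc4)ccc3c2=O)cc1OC`) gives 6180 nM, and compound 3 (`COc1cc(OC)c(-c2coc3cc(OCc4ccccc4C#N)ccc3c2=O)cc1OC`) gives 980 nM, the lowest of the three numbers. The next compound, compound 4 (`COc1cc(OC)c(-c2coc3cc(OCc4cccc(F)c4)ccc3c2=O)cc1OC`), departs from compound 3 in one place: 3-fluorophenyl in place of 2-cyanophenyl on a saturated chain carbon bound to an oxygen on an aromatic ring. In other words, 3-fluorophenyl stands in place of 2-cyanophenyl on a saturated chain carbon bound to an oxygen on an aromatic ring.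

Among the measured compounds shown here, no measured compound carries 3-fluorophenyl, so the evidence for this change is indirect. The closest guide is what happens when 2-cyanophenyl is reached from other groups at this place. The data show a 2.0-fold lower number from compound 1 to compound 3 (0.31 log units; beyond the scatter) and a 6.3-fold lower number from compound 2 to compound 3 (0.80 log units; beyond the scatter). Both measured compounds without 2-cyanophenyl thus stand higher than compound 3, and a 3.1-fold higher number from compound 1 to compound 2 (0.49 log units; beyond the scatter) shows that the choice of group here matters in this read-out. On that basis, losing 2-cyanophenyl is expected to raise the number by a modest amount. The expected change is a 2.4-fold higher number from compound 3 to compound 4 (0.39 log units; beyond the scatter), of a size similar to the measured steps. For compound 4 the estimated value is 2400 nM, with an expected range from 900 nM to 6500 nM.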

Compound 4, half-maximal inhibitory concentration: 3510 nM
Estimate against measurement, compound 4: 1.5-fold (0.17 log units) below, and the stated range covers the measured number.
By their numbers in this assay, from the lowest: compound 3; then compounds 1, 4 and 2 (each within the scatter of the next, the first and the last beyond it).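

In this assay the swap of 2-cyanophenyl for 3-fluorophenyl gives a 3.6-fold higher number from compound 3 to compound 4 (0.55 log units; beyond the scatter) and so confirms with a third comparison that compound 3 stands apart, since its steps to all the other compounds shown are beyond the scatter. Among the compounds shown here, the fluorine-bearing ring, the first group at this place with neither a nitrile nor a methyl, does not separate from either of the other two groups: the data give a 1.8-fold lower number from compound 2 to compound 4 (0.25 log units; within the scatter) and a 1.8-fold higher number from compound 1 to compound 4 (0.24 log units; within the scatter) and so place compound 4 within the scatter of both compound 1 and compound 2, even though those two differ from each other beyond it. At this place, then, only 2-cyanophenyl is clearly set apart from 3-fluorophenyl, and nothing here accounts for that gap.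

With a single fluorine-bearing compound, the data cannot show how much of this step comes from losing the nitrile and how much from where the new group sits on the ring. For the compounds shown here, it also remains open whether an amine or a carboxylic acid on the phenyl ring, or a longer chain carrying that ring, would give a number lower than the one for compound 3 at 980 nM in this read-out.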